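Swapping Bromo for Fluoro in a Weakly Cytotoxic Series

The compounds below may be only part of what the source reports. "The series", "measured", "known", "first", "only" and "open" are said of these compounds alone.

Compound 1 `CCn1c(/C=C2/C(=O)Nc3ccc(Br)cc32)nc2ccccc21` gives 42700 nM in a functional assay on PC-3 cells (Homo sapiens) for cytotoxicity, read by MTT assay, with a stated time of 48 h; a lower number here means a stronger inhibitor, a higher number a weaker inhibitor. Compound 2 `CCn1c(/C=C2/C(=O)Nc3ccc(C)cc32)nc2ccccc21`, with methyl in place of bromo on an aromatic carbon, gives 38600 nM in this assay; the step of a 1.1-fold lower number from compound 1 to compound 2 (0.04 log units; within the scatter) lies within the scatter. Compound 3 `Cn1c(/C=C2/C(=O)Nc3ccc(Br)cc32)nc2ccccc21` has hydrogen in place of methyl on a saturated chain carbon bound to an aromatic nitrogen. In this assay compound 3 is reported only as a limit, > 50000 nM, the ceiling at which one of the three values sits (the limit of > 50000 nM in this assay, at which 1 of the 3 values shown sits). The step of an at least 1.1-fold higher number from compound 1 to compound 3 (0.06 log units; that floor lies within the scatter) has its floor within the scatter. Compound 4 `Cn1c(/C=C2/C(=O)Nc3ccc(F)cc32)nc2ccccc21` carries the change (fluoro in place of bromo on an aromatic carbon). Within the data shown here, the one comparable step, a 1.1-fold lower number from compound 1 to compound 2 (0.04 log units; within the scatter), replaced bromo on an aromatic carbon without moving beyond the scatter, so the expected step that the limit leaves unreadable from compound 3 to compound 4 is small. Compound 4 is therefore estimated at 60000 nM, between 30000 nM and 150000 nM, and may again be reported only as a limit.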

Compound 4, half-maximal inhibitory concentration: 34300 nM
For compound 4 the middle estimate is 1.7-fold (0.24 log units) above the measured one; the range from low to high includes it.
By their numbers in this assay, from the lowest: compounds 4, 2 and 1 (each within the scatter of the next). At a limit, above all of these: compound 3.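

Fluoro in place of bromo on this aromatic carbon gives an at least 1.4-fold lower number from compound 3 to compound 4 (0.16 log units; that floor lies within the scatter) in this assay, so this swap yields a readable number where the bromo analogue gave none. The floor of that step lies within the scatter, so no real gain from fluoro is shown. The true size of the step stays unknown because compound 3 is reported only as a limit: the limit of > 50000 nM in this assay, at which 1 of the 4 values shown sits.

Still open, going by these compounds, is whether an amine or a carboxylic acid on this aromatic carbon would move the number beyond the scatter. A longer chain on the aromatic nitrogen is equally untested here.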